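A few compounds are considered here, and "the series" means these few. Any claim that something is new, unique, unknown or untested is made for them only; others in the source may bear on it.

In a functional assay on MCF7 cells (Homo sapiens) for inhibition, read by sulforhodamine B assay (a higher number here means a weaker inhibitor of growth, a lower number a stronger inhibitor of growth), compound 1 `c1ccc(-c2ccc(-c3ccc(-c4nc5ccccc5[nH]4)cc3)cc2)cc1` gives 39200 nM and compound 2 `FC(F)(F)Oc1ccc(-c2ccc(-c3ccc(-c4nc5ccccc5[nH]4)cc3)cc2)cc1` gives 38400 nM with the two numbers within the scatter of each other. The change to compound 3 `Oc1ccc(-c2ccc(-c3ccc(-c4nc5ccccc5[nH]4)cc3)cc2)cc1` is hydrogen in place of trifluoromethyl on an oxygen on an aromatic ring and reads trifluoromethoxy to hydroxy. Among the compounds with values here, the only measured step is a 1.0-fold lower number from compound 1 to compound 2 (0.01 log units; within the scatter) and it stays within the scatter, while no hydroxy compound has been measured yet. No shift beyond the scatter is therefore expected in this assay and the estimated step is a 1.2-fold lower number from compound 2 to compound 3 (0.08 log units; within the scatter) with wide uncertainty. Compound 3 is estimated at 32000 nM with 12000 nM to 70000 nM as the expected range.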

Compound 3, concentration for 50% growth inhibition: 30500 nM
For compound 3 the middle estimate is 1.0-fold (0.02 log units) above the measured one, and the stated range covers the measured number.
By their numbers in this assay, from the lowest: compounds 3, 2 and 1 (each within the scatter of the next).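

In this assay hydroxy in place of trifluoromethoxy gives a 1.3-fold lower number from compound 2 to compound 3 (0.10 log units; within the scatter) and hydroxy in place of hydrogen on the aromatic carbon gives a 1.3-fold lower number from compound 1 to compound 3 (0.11 log units; within the scatter) at the same position. This position has now taken hydrogen, trifluoromethoxy and hydroxy with no step beyond the scatter, so a hydroxy oxygen carrying hydrogen adds no readable shift. No supporting data bear on this flat reading. As far as these compounds go, whether an amine, a carboxylic acid or a longer chain here would move the number beyond the scatter stays open. Changes to the shared core also remain open.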